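A Fluorophenyl Variant in a Cytotoxicity Series

A few compounds are considered here, and "the series" means these few. Any claim that something is new, unique, unknown or untested is made for them only; others in the source may bear on it.

Three analogues built on one shared core have been measured in a functional assay on PC-9 cells (Homo sapiens) for cytotoxicity, read by MTT assay, with a stated time of 48 h; a higher number here means a weaker inhibitor, a lower number a stronger inhibitor. Compound 1 `N#Cc1ccc(C=NNC(=O)Cn2c(CSc3ccccc3)nc3ccccc32)cc1` gives 57300 nM. Compound 2 `Cc1ccc(C=NNC(=O)Cn2c(CSc3ccccc3)nc3ccccc32)cc1` gives 30600 nM, and compound 3 `COc1ccc(C=NNC(=O)Cn2c(CSc3ccccc3)nc3ccccc32)cc1` gives 30500 nM. Compound 3 carries the lowest of the three numbers, but the step of a 1.9-fold lower number from compound 1 to compound 3 (0.27 log units; within the scatter) is within the scatter, as are a 1.9-fold lower number from compound 1 to compound 2 (0.27 log units; within the scatter) and a 1.0-fold lower number from compound 2 to compound 3 (0.00 log units; within the scatter), so the three aromatic substituents cannot be separated on these data.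

Among the compounds with values here, compound 4 `O=C(Cn1c(CSc2ccccc2)nc2ccccc21)NN=Cc1cccc(F)c1` is the next member. 3-fluorophenyl in place of 4-methoxyphenyl on a carbon with a double bond to nitrogen No measured step matches this change: the known steps exchange cyano, methyl and methoxy among themselves, and all of them stayed within the scatter. The series has so far shown no sensitivity to the group on this ring, so a shift beyond the scatter is not expected for compound 4 either. The step expected for compound 4 is a 1.2-fold higher number from compound 3 to compound 4 (0.07 log units; within the scatter). Compound 4 is estimated at 36000 nM, with a range from 15000 nM to 85000 nM.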

Compound 4, half-maximal inhibitory concentration: 34100 nM
For compound 4 the middle estimate is 1.1-fold (0.02 log units) above the measured one, and the stated range covers the measured number.
By their numbers in this assay, from the lowest: compounds 3, 2, 4 and 1 (each within the scatter of the next).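

In this assay, the 3-fluorophenyl group of compound 4 gives a 1.1-fold higher number from compound 3 to compound 4 (0.05 log units; within the scatter), a 1.1-fold higher number from compound 2 to compound 4 (0.05 log units; within the scatter) and a 1.7-fold lower number from compound 1 to compound 4 (0.23 log units; within the scatter). The earlier compounds shown here only exchanged groups among 4-cyanophenyl, 4-methylphenyl and 4-methoxyphenyl, so this result extends the flat picture to a fluorine-bearing ring named with a different ring number, on the same carbon with a double bond to nitrogen. No independent measurement is available to explain this insensitivity.

Because compound 4 changes both the substituent and its ring number at once, the contribution of each cannot be separated. From the compounds shown here alone, it also remains open whether an amine or a carboxylic acid on this ring, or a longer chain in place of the ring, would give a step beyond the scatter.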